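Replacing the charged ring substituent on compound 2

The source may report more compounds than this note shows. Statements on the series, on what has been measured and on what is new or still open speak of the compounds shown alone.

Compound 2 `COc1ccc(-c2nc(/N=C(\N)[N+]3(C)CCCCC3)sc2-c2ccc(OC)cc2)cc1` carries, on the shared core, a group of 10 heavy atoms with one six-membered non-aromatic ring and a net positive charge. In a functional assay with Oryctolagus cuniculus as the target (a lower number here means a stronger inhibitor, a higher number a weaker inhibitor), compound 2 reaches only a limit, > 1000 nM, and so sits at the limit of > 1000 nM in this assay, at which 1 of the 3 values shown sits, among the three measured values. The change to compound 4 `COc1ccc(-c2nc(C(=O)N=C(N)N)sc2-c2ccc(OC)cc2)cc1` is a group of 6 heavy atoms (2 carbon, 3 nitrogen, 1 oxygen; no ring) in place of a group of 10 heavy atoms (7 carbon, 3 nitrogen; one six-membered non-aromatic ring with 1 hetero atom), on an aromatic carbon.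

Two measured steps surround this position. Compound 1 `COc1ccc(-c2nc(/N=C(\N)N(C)C)sc2-c2ccc(OC)cc2)cc1`, which bears the small uncharged group of 3 heavy atoms, gives 37 nM in this assay, and the step of an at least 27-fold higher number from compound 1 to compound 2 (1.43 log units; beyond the scatter) shows how much the ring-bearing charged group weakens inhibition. Compound 3 `CNC(=O)NCc1nc(-c2ccc(OC)cc2)c(-c2ccc(OC)cc2)s1`, with a neutral group of 6 heavy atoms on the same aromatic carbon, gives 22 nM, and the step of an at least 45-fold lower number from compound 2 to compound 3 (1.65 log units; beyond the scatter) runs in the opposite direction. Compound 4 resembles compound 1 and compound 3 in size and in lacking a charge, so a large lowering of the number is expected from compound 2, an at least 20-fold lower number from compound 2 to compound 4 (1.30 log units; beyond the scatter), because the steps of an at least 27-fold higher number from compound 1 to compound 2 (1.43 log units; beyond the scatter) and an at least 45-fold lower number from compound 2 to compound 3 (1.65 log units; beyond the scatter) both tie the weak result to the charged ring group. Compound 4 is therefore estimated at 50 nM, within 15 nM to 300 nM.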

Compound 4, half-maximal inhibitory concentration: > 100 nM
Compound 4 ended at the assay's limit; the forecaster's own chance of this, stated with the estimate: 10%; middle value at least 2.0-fold (0.30 log units) away from the limit.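

In this assay compound 4 is held only by a limit, so the result fixes a floor and not a number: the limit of > 100 nM in this assay, at which 1 of the 4 values shown sits.

Having no net charge and a group of 6 heavy atoms on this aromatic carbon is therefore not enough on its own to match the two stronger compounds, as an at least 4.5-fold higher number from compound 3 to compound 4 (0.65 log units; beyond the scatter) and an at least 2.7-fold higher number from compound 1 to compound 4 (0.43 log units; beyond the scatter) both show, each beyond the scatter; the earlier compounds, in which only the charged ring group stood out as weak, could not show this. How compound 4 compares with compound 2 cannot be read, because compound 2 is also held only by a limit: the limit of > 1000 nM in this assay, at which 1 of the 4 values shown sits.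

Going by these compounds, what stays open is how far compound 4 lies past its limit, and whether the carbonyl in the group entering at this position is what sets it apart from compound 1. Also open, on these data alone, is how a simple amine, a carboxylic acid or a longer chain on this same aromatic carbon, next to the ring nitrogen and the ring sulfur, would read in this assay.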